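Nicotinamide thiocarbamate series: methoxy for hydrogen

The source may report more compounds than this note shows. Statements on the series, on what has been measured and on what is new or still open speak of the compounds shown alone.

Working notes on three measured compounds and one awaiting measurement. The read-out is an ADME assay for pharmacokinetics, in phosphate buffer, with a stated time of 0.25 h, tested at 60 uM, at a dose of 60 microM; on this read-out higher numbers stand for higher exposure at the dose given and lower numbers for lower exposure. Compound 1 `O=C(NCCOC(=S)Nc1ccc([N+](=O)[O-])cc1Cl)c1cccnc1` gives 16200 nM in this assay. Compound 2 `O=C(Oc1ccc(-c2cc(=S)ss2)cc1)c1cccnc1`, which carries a different core, gives 12000 nM in this assay. Compound 3 `O=C(NCCOC(=S)Nc1ccccc1)c1cccnc1` gives 17800 nM in this assay; the numbers for compound 1 and compound 2 both lie within the usual scatter of that for compound 3, so the three measured compounds cannot be told apart on this read-out.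

Compound 4 `COc1ccc(NC(=S)OCCNC(=O)c2cccnc2)cc1` is not yet measured. Its difference from compound 3 is methoxy in place of hydrogen on an aromatic carbon. Going by the values given here, no pair of measured compounds differing in a single place is available, so there is no measured step on which to size this change. Given that the three measured numbers, including the change of core between compound 3 and compound 2, all fall within the scatter, the expectation for compound 4 is a step from compound 3 of a 1.0-fold lower number from compound 3 to compound 4 (0.02 log units; within the scatter), that is, nothing beyond the scatter in either direction. Compound 4 is therefore estimated at 17000 nM in this assay, with a plausible range from 9000 nM to 34000 nM.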

Compound 4, maximal plasma concentration: 14700 nM
The estimate for compound 4 lay 1.2-fold (0.06 log units) above the measured number, within the range that was stated.
By their numbers in this assay, from the lowest: compounds 2, 4, 1 and 3 (each within the scatter of the next).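

In this assay, going by these compounds alone, the change of methoxy in place of hydrogen on an aromatic carbon, para to a large group, gives a 1.2-fold lower number from compound 3 to compound 4 (0.08 log units; within the scatter) and so supplies the first measured step that differs in one place. The earlier compounds shown here offered no such pair; this one shows that at this position an added methoxy, with its two heavy atoms, one hydrogen-bond acceptor and no net charge, moves the read-out by no more than the usual scatter of repeated measurements. No independent measurement is available that would explain this outcome, so it stands as an observation for this single pair only.

On these data alone, whether the same holds for other groups on this carbon, such as an amine, a carboxylic acid or a longer alkoxy chain, stays open, as does whether any of them would move the number beyond the scatter. Also open, as far as these compounds go, is whether methoxy on another carbon of the same ring, or on the ring of compound 1 with its other substituents, would behave as it does here.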